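The source may hold more compounds than are shown below. What is called first, only, known or untested is meant among the compounds shown, and "the series" means these compounds.

Measured in a functional assay on RS4-11 cells (Homo sapiens) for inhibition, read by CCK-8 assay, with a stated time of 72 h; on this read-out higher numbers stand for weaker inhibition and lower numbers for stronger inhibition:
Compound 1 `CCN(CC)CCCNc1ccc(S(=O)(=O)NC(=O)c2ccc(N3CCN(CC4=C(c5ccc(C(F)(F)F)cc5)CC(C)(C)CC4)CC3)cc2Oc2cnc3[nH]ccc3c2)cc1[N+](=O)[O-]`: 3 nM
Compound 2 `CC1(C)CCC(CN2CCN(c3ccc(C(=O)NS(=O)(=O)c4ccc(NCC5CCOC5)c([N+](=O)[O-])c4)c(Oc4cnc5[nH]ccc5c4)c3)CC2)=C(c2ccc(C(F)(F)F)cc2)C1`: 24.2 nM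
Compound 3 `CC1(C)CCC(CN2CCN(c3ccc(C(=O)NS(=O)(=O)c4ccc(OCC5CCOCC5)c([N+](=O)[O-])c4)c(Oc4cnc5[nH]ccc5c4)c3)CC2)=C(c2ccc(C(F)(F)F)cc2)C1`: 5.9 nM

Compound 3 lies within the scatter of compound 1, as shown by a 2.0-fold higher number from compound 1 to compound 3 (0.29 log units; within the scatter). It differs beyond the scatter from compound 2, as shown by a 4.1-fold lower number from compound 2 to compound 3 (0.61 log units; beyond the scatter).

Compound 4 `CN1CCC(COc2ccc(S(=O)(=O)NC(=O)c3ccc(N4CCN(CC5=C(c6ccc(C(F)(F)F)cc6)CC(C)(C)CC5)CC4)cc3Oc3cnc4[nH]ccc4c3)cc2[N+](=O)[O-])C1` carries this change: 1-methylpyrrolidin-3-yl in place of oxan-4-yl on a saturated chain carbon bound to an oxygen on an aromatic ring. In words, it has 1-methylpyrrolidin-3-yl in place of oxan-4-yl on a saturated chain carbon bound to an oxygen on an aromatic ring, so the (1-methylpyrrolidin-3-yl)methoxy group replaces the (oxan-4-yl)methoxy group.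

Going by the values given here, no measured step makes this exact exchange. The step to compound 3 from compound 1, which carries a diethylamino chain, stays within the scatter. Against that, an 8.1-fold higher number from compound 1 to compound 2 (0.91 log units; beyond the scatter) goes beyond it, so this substituent can move the number, and compound 2 is the exception among the three.

Compound 4 keeps the methoxy link of compound 3, so no change beyond the scatter is expected in this assay. The expected size is a 1.2-fold lower number from compound 3 to compound 4 (0.07 log units; within the scatter). The estimate for compound 4 is 5 nM, with an expected range of 2 nM to 14 nM.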

Compound 4, half-maximal inhibitory concentration: 10 nM
Compound 4: middle estimate off by 2.0-fold (0.30 log units), on the low side, and the stated range covers the measured number.
By their numbers in this assay, from the lowest: compounds 1, 3 and 4 (each within the scatter of the next, the first and the last beyond it); then compound 2.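

In this assay, the exchange of oxan-4-yl for 1-methylpyrrolidin-3-yl on a saturated chain carbon bound to an oxygen on an aromatic ring stays within the scatter (a 1.7-fold higher number from compound 3 to compound 4 (0.23 log units; within the scatter)), so at this position a five-membered nitrogen ring and a six-membered oxygen ring are not told apart by this read-out. Compound 4 still separates from both amino-linked compounds (a 2.4-fold lower number from compound 2 to compound 4 (0.38 log units; beyond the scatter)) (a 3.3-fold higher number from compound 1 to compound 4 (0.52 log units; beyond the scatter)), whereas compound 3 lies within the scatter of compound 1, though these two gaps are modest. No supporting measurement bears on this result.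

Open, going by these compounds, is whether a morpholine ring on the same chain carbon would stay within the scatter of compound 3. Also open, on these data alone, is how a diethylamino chain would read on the oxygen link.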